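The source may hold more compounds than are shown below. What is called first, only, known or untested is meant among the compounds shown, and "the series" means these compounds.

Compound 1 `CC#CC(CC(=O)O)c1ccc(OCc2ccc3nc(-c4ccc(CC)cc4)cn3c2)cc1` gives 496 nM in an assay on isolated protein for agonist activity at Free fatty acid receptor 1 (Homo sapiens); on this read-out lower numbers stand for an effect already at smaller amounts and higher numbers for an effect only at larger amounts of compound.
Compound 2 `CC#CC(CC(=O)O)c1ccc(OCc2ccc3nc(-c4ccc(F)cc4F)cn3c2)cc1` gives 825 nM in this assay.

Compound 2 gives the larger of these two numbers, yet the step of a 1.7-fold higher number from compound 1 to compound 2 (0.22 log units; within the scatter) lies within the scatter, so the two compounds are not told apart. Compound 3 `CC#CC(CC(=O)O)c1ccc(OCc2ccc3nc(-c4ccc(C)cc4C)cn3c2)cc1` carries 2,4-dimethylphenyl in place of 2,4-difluorophenyl on an aromatic carbon. Going by the values given here, only that one measured step bears on this change, and it was small, so no step beyond the scatter is expected in this assay. Compound 3 is therefore estimated at about 600 nM, with a range from 250 nM to 1500 nM, which means an expected step of a 1.4-fold lower number from compound 2 to compound 3 (0.14 log units; within the scatter).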

Compound 3, half-maximal effective concentration: 316 nM
Beside the measured number, compound 3's estimate is 1.9-fold (0.28 log units) above it; the range from low to high includes it.
By their numbers in this assay, from the lowest: compounds 3, 1 and 2 (each within the scatter of the next, the first and the last beyond it).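

Going by these compounds alone, putting 2,4-dimethylphenyl in place of 2,4-difluorophenyl gives a 2.6-fold lower number from compound 2 to compound 3 (0.42 log units; beyond the scatter) in this assay and is the first step beyond the scatter at this place, so the choice of substituents on this phenyl ring can shift the number. Putting it in place of 4-ethylphenyl gives a 1.6-fold lower number from compound 1 to compound 3 (0.20 log units; within the scatter) and does not tell those two groups apart. The data shown offer no explanation for either result. Still open, on these data alone, is whether the larger step comes from one ring substituent or both, and how 4-methylphenyl or 2,4-dichlorophenyl would compare.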